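The source may hold more compounds than are shown below. What is called first, only, known or untested is meant among the compounds shown, and "the series" means these compounds.

Working notes on the series in an in vitro functional assay on 1321-N1 cells for agonist activity at Free fatty acid receptor 1 (Homo sapiens), read by fluorescence, spectrophotometry and calcium flux; a higher number here means a larger maximal response, a lower number a smaller maximal response. Of the compounds shown here, three have been measured. Compound 1 `O=C(O)CCc1ccc(C#Cc2ccnc(Cl)c2Cc2ccccc2)cc1` gives 101%. Compound 2 `COc1nccc(C#Cc2ccc(CCC(=O)O)cc2)n1` gives 109%. Compound 3 `O=C(O)CCc1ccc(C#Cc2ccnc(F)c2)cc1` gives 98%, the smallest of the three numbers; the gap to compound 1 lies within the scatter of repeated measurements, so the two are not separated, while compound 2 stands beyond the scatter above compound 3. Within the data shown here, no pair of measured compounds differs in a single place, so nothing more than these values can be read from them.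

The next compound is compound 4 `O=C(O)CCc1ccc(C#Cc2ccnc(Cl)c2)cc1`. Relative to compound 3 the change is chloro in place of fluoro on an aromatic carbon. All three measured numbers sit close to full efficacy, and compound 1, which also carries chloro on its core, gives 101%, so the step from compound 3 to compound 4 is expected to be none beyond the scatter, a number 2 percentage points higher from compound 3 to compound 4 (within the scatter). Compound 4 is therefore estimated at 100%, with a range from 88% to 112%.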

Compound 4, largest response reached (reported as efficacy), in percent of the reference or control that the assay uses: 94%
Estimate against measurement, compound 4: 6 percentage points above; the range from low to high includes it.
By their numbers in this assay, from the lowest: compounds 4, 3, 1 and 2 (each within the scatter of the next, the first and the last beyond it).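

In this assay, chloro in place of fluoro on an aromatic carbon next to the ring nitrogen gives a number 4 percentage points lower from compound 3 to compound 4 (within the scatter) and so does not separate the two halogens at this position. Hydrogen in place of benzyl on an aromatic carbon gives a number 7 percentage points lower from compound 1 to compound 4 (within the scatter) and so, with chloro present, shows no separable difference in maximal response with or without the benzyl group. No measurement available on these compounds offers an explanation for either step.

On these data alone, whether an amine or a nitrile in place of the halogen at this position would keep the response within the same scatter remains open. Also open, as far as these compounds go, is whether the two halogens or the benzyl group change potency, which a maximal response does not show.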